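The source may report more compounds than this note shows. Statements on the series, on what has been measured and on what is new or still open speak of the compounds shown alone.

Measured so far in an ADME assay on CHO cells for agonist activity at prostacyclin receptor (Homo sapiens), read by HTRF and cAMP accumulation; a higher number here means that more compound is needed for the effect, a lower number that less compound is needed:
- compound 1 `O=C(O)CCCC1=CC[C@@H]2[C@@H](/C=C/[C@@H](O)COc3ccccc3)[C@H](O)C[C@@H]2OC1`: > 10000 nM
- compound 2 `O=C(O)CC[C@@H]1CC[C@@H]2[C@@H](/C=C/[C@@H](O)COc3ccccc3)[C@H](O)C[C@@H]2OC1`: > 10000 nM

For compound 2 the value recorded in this assay is a limit of the assay, not a number. The value of compound 1 is likewise a limit. Within the data shown here, both sit at the limit of > 10000 nM in this assay, at which 2 of the 2 values shown sit, so no measured step between them can be sized.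

Compound 3 `O=C(O)CC[C@H]1CC[C@@H]2[C@@H](/C=C/[C@@H](O)COc3ccccc3)[C@H](O)C[C@@H]2OC1` differs from compound 2 by the two compounds have the same atoms and bonds and differ only in configuration as drawn: 1 of 7 stereo elements differ; a stereocentre at a saturated ring carbon is drawn S in compound 2 and R in compound 3. Among the measured compounds shown here, no step between measured compounds covers such a change, so the direction cannot be read from the data; the expectation is for compound 3 to remain near the limit where compound 2 sits.

Compound 3 is estimated at 15000 nM, with a range from 5000 nM to 50000 nM. The expected change a step that the limit leaves unreadable from compound 2 to compound 3 is none beyond the scatter.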

Compound 3, half-maximal effective concentration: > 10000 nM
Compound 3: only a limit was reported; the forecaster's own chance of this, stated with the estimate: 80%; the middle value is on the limit's open side.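

No step can be read between compound 2 and compound 3 in this assay: each value is a limit of the assay. The compounds shown leave open whether the configuration at the saturated ring carbon affects agonist activity at all.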